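The source may report more compounds than this note shows. Statements on the series, on what has been measured and on what is new or still open speak of the compounds shown alone.

In a functional assay on A549 cells (Homo sapiens) for cytotoxicity, read by resazurin assay, with a stated time of 72 h (on this read-out lower numbers stand for stronger inhibition and higher numbers for weaker inhibition), three compounds have been run. Compound 1 `COc1cc(/C=C/C(=O)Oc2ccc(OCc3c(-c4ccccc4)no[n+]3[O-])cc2)ccc1O` gives 3390 nM, compound 2 `O=C(/C=C/c1ccc(O)c(O)c1)OCc1c(-c2ccccc2)no[n+]1[O-]` gives 2710 nM, and compound 3 `COc1cc(/C=C/C(=O)OCc2ccc(OCc3c(-c4ccccc4)no[n+]3[O-])cc2)ccc1O` gives 17200 nM. Compound 2 thus carries the lowest of the three numbers, though compound 1 lies within the scatter of it; only compound 3 stands clearly higher, beyond the scatter.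

Compound 4 `COc1cc(/C=C/C(=O)OCc2c(-c3ccccc3)no[n+]2[O-])ccc1O` is the next to be measured. It differs from compound 2 in one place: methyl in place of hydrogen on an oxygen on an aromatic ring. Among the compounds with values here, no pair of measured compounds differing in a single place is available to size this change, so in this assay a step no larger than the scatter is expected, with no clear direction. On that basis compound 4 is estimated at 3300 nM, within 1600 nM to 7000 nM, a step of a 1.2-fold higher number from compound 2 to compound 4 (0.09 log units; within the scatter).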

Compound 4, half-maximal inhibitory concentration: 2060 nM
Beside the measured number, compound 4's estimate is 1.6-fold (0.20 log units) above it; the measured number falls inside the stated range.
By their numbers in this assay, from the lowest: compounds 4, 2 and 1 (each within the scatter of the next); then compound 3.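

Within the data shown here, replacing hydroxy with methoxy in this assay gives a 1.3-fold lower number from compound 2 to compound 4 (0.12 log units; within the scatter) and provides the first single-place comparison in this set. At this position, methyl in place of hydrogen on the oxygen leaves the 3,4-dihydroxyphenyl and 4-hydroxy-3-methoxyphenyl compounds indistinguishable within the scatter. Nothing available gives a reason for this result. Open, on these data alone, is whether an ethyl group or a longer chain on this oxygen, or an amine in place of the hydroxy, would shift the number beyond the scatter.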